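Ring-nitrogen substituent in the pendrin series: sulfonamide step

The source may report more compounds than this note shows. Statements on the series, on what has been measured and on what is new or still open speak of the compounds shown alone.

Measured so far:
- compound 1, `Cn1nc(COc2cc(F)cc(F)c2)c2c1CCN(C(=O)Nc1ccc(Cl)cc1)C2`, gives 3100 nM in an assay on cells for inhibition of Pendrin (Mus musculus), read by fluorescence, with a stated time of 10 min; a higher number here means a weaker inhibitor, a lower number a stronger inhibitor.
- compound 2, `Cn1nc(COc2cc(F)cc(F)c2)c2c1CCN(C(=S)Nc1ccc(Cl)cc1)C2`, reaches only the limit of this assay, > 10000 nM.
- compound 3, `Cn1nc(COc2cc(F)cc(F)c2)c2c1CCN(S(C)(=O)=O)C2`, likewise reaches only the limit, > 10000 nM.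

Going by the values given here, compound 1 carries (4-chlorophenyl)carbamoyl on the amine nitrogen of the ring and is the only member with a number; the other two stand at the limit of > 10000 nM in this assay, at which 2 of the 3 values shown sit. Exchanging the oxygen of that group for sulfur gives an at least 3.2-fold higher number from compound 1 to compound 2 (0.50 log units; beyond the scatter). Replacing the whole group by methylsulfonyl gives an at least 3.2-fold higher number from compound 1 to compound 3 (0.50 log units; beyond the scatter). Between the two, a step that the two limits leave unreadable from compound 2 to compound 3.

Compound 4, `Cn1nc(COc2cc(F)cc(F)c2)c2c1CCN(S(=O)(=O)c1ccc(Cl)cc1)C2`, differs from compound 1 by (4-chlorophenyl)sulfonyl in place of (4-chlorophenyl)carbamoyl on an amine nitrogen in a ring. Both measured departures from the (4-chlorophenyl)carbamoyl of compound 1 ran to a higher number. Compound 4 keeps the chlorophenyl ring of compound 1 but takes the sulfonyl of compound 3, and compound 3 alone sat at the limit. A modest step towards a higher number in this assay is therefore expected for compound 4, a 2.9-fold higher number from compound 1 to compound 4 (0.46 log units; beyond the scatter), with a real chance that only a limit is returned. Compound 4 is estimated at 9000 nM, in a range from 3000 nM to 30000 nM.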

Compound 4, half-maximal inhibitory concentration: > 10000 nM
Compound 4: only a limit was reported; the forecaster's own chance of this, stated with the estimate: 50%; middle value at least 1.1-fold (0.04 log units) away from the limit.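

With the 4-chlorophenyl ring kept and only its link to the amine nitrogen in a ring changed, (4-chlorophenyl)sulfonyl in place of (4-chlorophenyl)carbamoyl gives an at least 3.2-fold higher number from compound 1 to compound 4 (0.50 log units; beyond the scatter) in this assay. The 4-chlorophenyl ring alone therefore does not preserve a measurable value at this position, as compound 3 without that ring could not show. Among the four compounds shown, only the (4-chlorophenyl)carbamoyl of compound 1 gives a number, and the steps from compound 2 and from compound 3 to compound 4 cannot be read, leaving most of this small set at one limit: the limit of > 10000 nM in this assay, at which 3 of the 4 values shown sit.

On these data alone, whether the carbonyl or the amide hydrogen of compound 1 matters more remains open, and a 4-chlorobenzoyl group, which has the carbonyl without the amide hydrogen, would help separate the two. Also open, as far as these compounds go, is whether any group on this nitrogen improves on compound 1, which gives 3100 nM, for example a carbamoyl carrying cyclohexyl or 4-methoxyphenyl in place of 4-chlorophenyl.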